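A few compounds are considered here, and "the series" means these few. Any claim that something is new, unique, unknown or untested is made for them only; others in the source may bear on it.

Working notes on the series, cytotoxicity track.

Compound 2 `CCCC[C@H](CCn1cncn1)c1ccccc1` gives 50.2 ug/mL in an ADME assay on HEp-2 cells (Homo sapiens) for cytotoxicity, read by MTT assay, with a stated time of 3 days; on this read-out lower numbers stand for higher toxicity in this test and higher numbers for lower toxicity in this test. Compound 1 `CCC[C@H](CCn1cncn1)c1ccccc1` gives 58.4 ug/mL in this assay, and compound 3 `CCCC[C@@H](CCn1cncn1)c1ccccc1` gives 40.8 ug/mL. Compound 2 thus gives the second highest of the three numbers, yet both other numbers lie within the scatter of it: the step of a 1.2-fold lower number from compound 1 to compound 2 (0.07 log units; within the scatter) and the step of a 1.2-fold lower number from compound 2 to compound 3 (0.09 log units; within the scatter), the second pair being one where (the fact that compounds 2 and 3 differ only in the configuration as drawn).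

Compound 4 `CCCC[C@H](CCn1cncn1)c1ccc(F)cc1` is the next entry, differing from compound 2 by fluoro in place of hydrogen on an aromatic carbon. Neither measured step bears directly on a change at the aromatic ring: one adds a methyl on the saturated chain, the other inverts a stereocentre, and both stay within the scatter. For the measured compounds named here, with no measured step touching the ring and the two measured steps both small, no step beyond the scatter is expected in this assay for compound 4. The expected value for compound 4 is 45 ug/mL, with a range from 25 ug/mL to 90 ug/mL. This expectation corresponds to the step of a 1.1-fold lower number from compound 2 to compound 4 (0.05 log units; within the scatter).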

Compound 4, half-maximal cytotoxic concentration: 38.5 ug/mL
For compound 4 the middle estimate is 1.2-fold (0.07 log units) above the measured one, and the stated range covers the measured number.
By their numbers in this assay, from the lowest: compounds 4, 3, 2 and 1 (each within the scatter of the next).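

In this assay the change on the aromatic ring, para to a large group, gives a 1.3-fold lower number from compound 2 to compound 4 (0.12 log units; within the scatter) and so stays within the scatter, as the steps on the chain and at the stereocentre do. At this position, then, fluoro in place of hydrogen produces no step beyond the scatter, and the ring joins the chain and the stereocentre as a place where a single change has left this read-out within the scatter. Nothing at hand bears on this ring change or on the size of its step.

As far as these compounds go, whether a larger group at this position, such as methoxy, an amine or a carboxylic acid, would behave the same remains open. Also open, from the compounds shown here alone, is whether fluoro gives a similar step on the shorter chain of compound 1 or in the configuration of compound 3.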